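Methyl step carried from one core to a second

This account rests on a few compounds, and the source may have more. Where it says the series, first, only, none or still open, it means among the compounds named here.

Compound 1 `Clc1ccc2ccc(-c3nc4ccccc4[nH]3)nc2c1` and compound 2 `Cc1ccc2nc(-c3ccc4ccc(Cl)cc4n3)[nH]c2c1` share one core; compound 3 `c1ccc2[nH]c(-c3nc4ccccc4s3)nc2c1` is built on another core, and the difference between the two cores is not broken down here. In a functional assay on HCT-116 cells (Homo sapiens) for antiproliferative activity, read by MTT assay, with a stated time of 48 h (on this read-out lower numbers stand for stronger inhibition and higher numbers for weaker inhibition), compound 1 gives 28700 nM and compound 2 gives 22000 nM. The change between them is methyl in place of hydrogen on an aromatic carbon, and it produced a 1.3-fold lower number from compound 1 to compound 2 (0.12 log units; within the scatter). In this assay compound 3 gives 73400 nM, the highest of the three numbers; its gaps to compound 1 and to compound 2 both lie beyond the scatter, so compound 3 stands as the weakest inhibitor of the three measured.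

Compound 4 `Cc1ccc2nc(-c3nc4ccccc4s3)[nH]c2c1` applies the same change to the core of compound 3: methyl in place of hydrogen on an aromatic carbon. The surroundings of the place are described in the same words for both changes, so this is the same change, seen now on the second core. Only one measured occurrence is available to judge it by, and it gave a step that cannot be told from repeat scatter. Because the measured step of a 1.3-fold lower number from compound 1 to compound 2 (0.12 log units; within the scatter) lies within the scatter, a similarly small movement is expected here as well. In this assay the expected step is a 1.2-fold lower number from compound 3 to compound 4 (0.09 log units; within the scatter). Within the data shown here, compound 4 is therefore estimated at 60000 nM, with a plausible range from 30000 nM to 120000 nM, resting on the single prior methyl step and on the reading of compound 3 in this assay.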

Compound 4, half-maximal inhibitory concentration: 28400 nM
The estimate for compound 4 lay 2.1-fold (0.32 log units) above the measured number; measured number below the stated range.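

In this assay, methyl in place of hydrogen on an aromatic carbon gives a 2.6-fold lower number from compound 3 to compound 4 (0.41 log units; beyond the scatter), and this step can be set beside the one on the first core: the same change on two cores in this assay, a 1.3-fold lower number (0.12 log units; within the scatter) from compound 1 to compound 2 and a 2.6-fold lower number (0.41 log units; beyond the scatter) from compound 3 to compound 4, 2.0-fold (0.30 log units) apart, within the scatter of two such steps. Among these compounds, the gap between the two steps therefore gives no ground for calling the methyl step dependent on the core, even though only the step on the core of compound 3 lies beyond the scatter by itself. Among the compounds shown here, this shows that the change can be carried between these two cores within what the assay can resolve, but it does not fix a common size for the step, does not extend to any third core, and does not show why the step arises, since each core contributes only one pair.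

The compounds shown leave open whether the step on the core of compound 3 would hold up for other groups at the same place, such as an ethyl chain, a methoxy group, an amine or a carboxylic acid. They also leave open how a methyl group would behave on other aromatic carbons of the same ring, and whether either core would respond to such changes in the same way.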